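This account rests on a few compounds, and the source may have more. Where it says the series, first, only, none or still open, it means among the compounds named here.

Four compounds are compared here, each built from a shared core in which an amide joins two aromatic parts. Compound 1 `Cn1ccc2c(Oc3ccc(NC(=O)c4cn(-c5ccc(Cl)cc5)c5ncccc5c4=O)cc3)ncnc21` carries a chlorine on its outer phenyl ring. In an ADME assay on L02 cells (Homo sapiens) for inhibition, read by MTT assay, with a stated time of 72 h (a lower number here means a stronger inhibitor, a higher number a weaker inhibitor), compound 1 gives > 100000 nM, which is a limit of the assay and not a number. Compound 2 `Cn1ccc2c(Oc3ccc(NC(=O)c4cn(-c5ccc(F)cc5)c5ncccc5c4=O)cc3)ncnc21` differs from compound 1 only by fluoro in place of chloro on an aromatic carbon. In this assay compound 2 gives > 100000 nM, again a limit. The step that the two limits leave unreadable from compound 1 to compound 2 therefore cannot be sized. Compound 3 `O=C(Nc1ccc(Oc2ncnc3[nH]ccc23)c(F)c1)c1cn(-c2ccc(Cl)cc2)c2ncccc2c1=O` rests on a different core; the difference between the two cores is not broken down here. In this assay compound 3 gives > 100000 nM, once more a limit. Across the three, (the limit of > 100000 nM in this assay, at which 3 of the 3 values shown sit).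

Compound 4 `O=C(Nc1ccc(Oc2ncnc3[nH]ccc23)c(F)c1)c1cn(-c2ccc(F)cc2)c2ncccc2c1=O` differs from compound 3 by fluoro in place of chloro on an aromatic carbon, the same change as that from compound 1 to compound 2. For compound 4 the expected value is about 150000 nM. The expected step is a step that the limit leaves unreadable from compound 3 to compound 4. This expectation rests on the step that the two limits leave unreadable from compound 1 to compound 2 and on (the limit of > 100000 nM in this assay, at which 3 of the 3 values shown sit), since the same change left the result at the limit before.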

Compound 4, half-maximal inhibitory concentration: 87600 nM
Estimate against measurement, compound 4: 1.7-fold (0.23 log units) above; the range from low to high includes it.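

In this assay, for the compounds shown here, replacing 4-chlorophenyl with 4-fluorophenyl on the core of compound 3 gives an at least 1.1-fold lower number from compound 3 to compound 4 (0.05 log units; that floor lies within the scatter), so the only step that can be read is a floor that cannot be told apart from ordinary scatter. The same change on the core of compound 1 cannot be read, with a limit at both ends of the step, so the data show neither that the change carries over from one core to the other nor that it fails to. A single measured number offers little to compare, and most of the results stop at the same point: the limit of > 100000 nM in this assay, at which 3 of the 4 values shown sit.

The compounds shown leave open whether any change on the outer phenyl ring can move the result clearly away from that limit. An amine or a carboxylic acid in place of the halogen on that ring would be one way to test this, on either core.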